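This account rests on a few compounds, and the source may have more. Where it says the series, first, only, none or still open, it means among the compounds named here.

Three compounds have been measured in a functional assay on the whole organism (blood, strain Wistar albino) for inhibition, with Rattus norvegicus as the target, read by colorimetric assay, with stated times of 15 min and 90 min, at a dose of 20 mg/kg by the oral route; on this read-out lower numbers stand for less inhibition and higher numbers for more inhibition at the one dose given (going by the name of the read-out):

compound 1, `CCCCNC(=O)NS(=O)(=O)c1ccc(-n2nc(-c3ccccc3)ccc2=O)cc1`: 111%
compound 2, `O=C(NC1CCCCC1)NS(=O)(=O)c1ccc(-n2nc(-c3ccccc3)ccc2=O)cc1`: 86.2%
compound 3, `CCCCNC(=O)NS(=O)(=O)c1ccc(-n2nc(-c3ccc(C)cc3)ccc2=O)cc1`: 109%

Compound 4, `Cc1ccc(-c2ccc(=O)n(-c3ccc(S(=O)(=O)NC(=O)NC4CCCCC4)cc3)n2)cc1`, has not been measured yet. Compound 1 and compound 2 differ in one place, (cyclohexyl in place of butyl on an amide-type nitrogen), and this brought a number 24.8 percentage points lower from compound 1 to compound 2 (beyond the scatter). Compound 3 carries a different core: methyl in place of hydrogen on an aromatic carbon, a change that brought only a number 2 percentage points lower from compound 1 to compound 3 (within the scatter), so compound 1 and compound 3 cannot be told apart on this read-out. Among the measured compounds shown here, compound 4 is reached from compound 3 by cyclohexyl in place of butyl on an amide-type nitrogen, which is the same change as the one between compound 1 and compound 2, made at a place described in the same words. For the measured compounds named here, the expectation for compound 4 therefore rests on the one earlier example: the step from compound 3 to compound 4 is estimated to be a number 25 percentage points lower from compound 3 to compound 4 (beyond the scatter), set beside the measured a number 24.8 percentage points lower from compound 1 to compound 2 (beyond the scatter), and starting from compound 3 at 109%. On that basis compound 4 is expected to give about 84% in this assay, most likely between 66% and 102%.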

Compound 4, a percentage reported as inhibition, in the whole organism at one dose (the size of the read-out at that dose, not a potency): 110%
Compound 4: the middle estimate sits 26 percentage points below what was measured, outside the stated range (above it).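

Cyclohexyl in place of butyl gave a number 1 percentage points higher from compound 3 to compound 4 (within the scatter) in this assay, so the drop seen on the core of compound 1 did not carry over to the core of compound 3: the same change on two cores in this assay, a number 24.8 percentage points lower (beyond the scatter) from compound 1 to compound 2 and a number 1 percentage points higher (within the scatter) from compound 3 to compound 4, 25.8 percentage points apart, beyond the scatter of two such steps

Read the other way, methyl in place of hydrogen gave a number 23.8 percentage points higher from compound 2 to compound 4 (beyond the scatter) when cyclohexyl was present, although it made no clear difference when butyl was present: the same change on two cores in this assay, a number 2 percentage points lower (within the scatter) from compound 1 to compound 3 and a number 23.8 percentage points higher (beyond the scatter) from compound 2 to compound 4, 25.8 percentage points apart, beyond the scatter of two such steps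

Across these four compounds, then, the two changes do not simply add up, and the effect of each depends on the other, but this rests on a single set of four compounds at one dose and does not show why the steps differ or whether the same holds elsewhere in the series.

The compounds shown leave open how a longer chain such as hexyl, or a smaller ring such as cyclopentyl, would behave on the amide-type nitrogen. They also leave open whether chloro or methoxy in place of methyl would make the cyclohexyl compounds respond as compound 4 does.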